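A few compounds are considered here, and "the series" means these few. Any claim that something is new, unique, unknown or untested is made for them only; others in the source may bear on it.

Going by the values given here, compound 1 `COc1ccccc1/C=c1\c(=O)[nH]/c(=C/c2cccc(Cl)c2Cl)c(=O)n1C` is the stronger of the two compounds measured so far. In a functional assay on A549 cells (Homo sapiens) for cytotoxicity, read by CCK-8 assay, with a stated time of 72 h (on this read-out higher numbers stand for weaker inhibition and lower numbers for stronger inhibition), compound 1 gives 200 nM, the lowest of the two numbers. Compound 2 `C=CCn1c(=O)/c(=C\c2ccccc2C(F)(F)F)[nH]c(=O)/c1=C\c1ccccc1OC` gives 7000 nM in this assay, a higher number that lies beyond the usual scatter; the two compounds differ in more than one place, so their values can only be set side by side. Compound 3 `COc1ccccc1/C=c1/[nH]c(=O)/c(=C\c2ccccc2OC)n(C)c1=O` has not yet been measured in this assay. It differs from compound 1 in a single place: 2-methoxyphenyl in place of 2,3-dichlorophenyl on a double-bonded chain carbon bound to an aromatic carbon. Among the compounds with values here, no measured pair covers this exact change, so the expectation rests on the two values shown and on the nature of the exchange. Compound 3 is expected to give a higher number than compound 1, a step of a 7.5-fold higher number from compound 1 to compound 3 (0.88 log units; beyond the scatter) that would lie beyond the scatter. Compound 3 is therefore estimated at 1500 nM, within a range from 400 nM to 6000 nM.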

Compound 3, half-maximal inhibitory concentration: 7000 nM
Compound 3: the middle estimate sits 4.7-fold (0.67 log units) below what was measured, and the stated range ends below it.
By their numbers in this assay, from the lowest: compound 1; then compounds 2 and 3 (each within the scatter of the next).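

Exchanging the 2,3-dichlorophenyl of compound 1 for 2-methoxyphenyl on a double-bonded chain carbon bound to an aromatic carbon gives, in this assay, a 35-fold higher number from compound 1 to compound 3 (1.54 log units; beyond the scatter), the first effect of a single exchange in this series. The value at this place therefore depends strongly on the group carried there, even though both groups have one six-membered aromatic ring of carbon only and the same number of heavy atoms, and only 2-methoxyphenyl adds a hydrogen-bond acceptor. Nothing available here accounts for the size of this step.

The compounds shown leave open whether both chlorines are needed, since none carries a single chlorine at this place. They also leave open how a bromine, a nitrile or an amine on this phenyl ring would compare.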